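Swapping the aryl ring on a shared thiosemicarbazone core

A few compounds are considered here, and "the series" means these few. Any claim that something is new, unique, unknown or untested is made for them only; others in the source may bear on it.

Two compounds share a core and differ only in the aromatic ring on the carbon with a double bond to nitrogen. Compound 1 `COc1ccc(/C=N\NC(=S)NC(C)(C)CCC[C@](C)(O)[C@@H]2CC=C(C)CC2)cc1` carries a 4-methoxyphenyl there, and in a functional assay on PCO3 cells (Homo sapiens) for cytotoxicity, read by sulforhodamine B assay (on this read-out higher numbers stand for weaker inhibition of growth and lower numbers for stronger inhibition of growth), compound 1 gives 76100 nM. Compound 2 `CC1=CC[C@@H]([C@@](C)(O)CCCC(C)(C)NC(=S)N/N=C\c2cccc([N+](=O)[O-])c2)CC1` carries a 3-nitrophenyl instead, and in this assay compound 2 gives 20700 nM. Among the measured compounds shown here, the change a 3.7-fold lower number from compound 1 to compound 2 (0.57 log units; beyond the scatter) is the only measured step, and it leaves compound 2 with the lowest number of the two.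

Compound 3 `CC1=CC[C@@H]([C@@](C)(O)CCCC(C)(C)NC(=S)N/N=C\c2ccccc2Cl)CC1` is the next variation: 2-chlorophenyl in place of 3-nitrophenyl on a carbon with a double bond to nitrogen. For the measured compounds named here, no measured step involves a 2-chlorophenyl, so that one step only shows that exchanging this ring can move the number in this assay beyond the scatter; it gives no direction for a chlorophenyl. The estimate therefore stays close to compound 2, and only a small step is expected, a 1.4-fold higher number from compound 2 to compound 3 (0.16 log units; within the scatter). Compound 3 is estimated to give 30000 nM in this assay, within a range from 10000 nM to 90000 nM.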

Compound 3, concentration for total growth inhibition: > 100000 nM
Compound 3: only a limit was reported; the forecaster's own chance of this, stated with the estimate: 10%; at least 3.3-fold (0.52 log units) between middle value and limit.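

Compound 3 gives a limit of the assay rather than a number: the limit of > 100000 nM in this assay, at which 1 of the 3 values shown sits.

Among the compounds shown here, putting 2-chlorophenyl in place of 3-nitrophenyl gives an at least 4.8-fold higher number from compound 2 to compound 3 (0.68 log units; beyond the scatter), so a ring exchange on this carbon can also raise the number in this assay, a direction that the single earlier step, which lowered it, did not show. Putting 2-chlorophenyl in place of 4-methoxyphenyl gives an at least 1.3-fold higher number from compound 1 to compound 3 (0.11 log units; that floor lies within the scatter), and since that floor lies within the scatter, the limit alone cannot settle how far compound 3 stands from compound 1.

With only three rings compared, the compounds shown cannot separate the effect of gaining a chlorine from that of losing the nitro group, and they offer no reason for the rise in the number. As far as these compounds go, it also stays open where a plain phenyl, or a phenyl carrying an amine or a carboxylic acid, would fall.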